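This account rests on a few compounds, and the source may have more. Where it says the series, first, only, none or still open, it means among the compounds named here.

Working notes on the series. In a functional assay on SiHa cells (Homo sapiens) for inhibition, read by CCK-8 assay, with a stated time of 72 h, tested at 1 uM (a lower number here means less inhibition of growth, a higher number more inhibition of growth at the concentration tested), compound 1 `Cc1ccc(NC(=O)C2(C(=O)Nc3ccc(Nc4ncc5cc(C(=O)N(C)C)n(C6CCCC6)c5n4)cc3)CC2)cc1` gives 37% and compound 2 `CN(C)C(=O)c1cc2cnc(Nc3ccc(NC(=O)C4(C(=O)Nc5ccc(O)cc5)CC4)cc3)nc2n1C1CCCC1` gives 69.5%. Compound 2 therefore holds the higher of the two numbers, and its gap to compound 1 lies beyond the scatter.

The next structure is compound 3 `CN(C)C(=O)c1cc2cnc(Nc3ccc(NC(=O)C4(C(=O)Nc5ccccc5)CC4)cc3)nc2n1C1CCCC1`. It differs from compound 2 as follows: hydrogen in place of hydroxy on an aromatic carbon. This is hydrogen in place of hydroxy on an aromatic carbon, so 4-hydroxyphenyl becomes phenyl.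

Among the measured compounds shown here, only one measured step bears on this change: a number 32.5 percentage points higher from compound 1 to compound 2 (beyond the scatter), a large step for hydroxy in place of methyl on an aromatic carbon. For the measured compounds named here, that step shows what replacing hydroxy with methyl does, but no measured pair isolates hydrogen, so the transfer is uncertain. A fall in this assay of moderate size is expected, probably smaller than that step, though a result close to either measured compound cannot be excluded. The estimated change is a number 17.5 percentage points lower from compound 2 to compound 3 (beyond the scatter). Compound 3 is expected at 52%, within an estimated range of 32% to 70%.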

Compound 3, percent growth inhibition at one concentration: 58%
The estimate for compound 3 lay 6 percentage points below the measured number; the measured number falls inside the stated range.
By their numbers in this assay, from the lowest: compound 1; then compound 3; then compound 2.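

In this assay taking away the hydroxy at this position gives a number 11.5 percentage points lower from compound 2 to compound 3 (beyond the scatter) and putting hydrogen in place of the methyl gives a number 21 percentage points higher from compound 1 to compound 3 (beyond the scatter) so compound 3 serves as the unsubstituted reference for this carbon of the six-membered aromatic ring, para to a large group. Set against that reference, the earlier hydroxy-for-methyl step resolves into two parts in opposite directions: hydroxy goes with a higher number than hydrogen, and methyl with a lower one, so the whole of that step cannot be credited to hydroxy alone. The compounds at hand offer nothing that accounts for either difference.

From the compounds shown here alone, whether this order extends beyond hydroxy, hydrogen and methyl remains open, and a methoxy group, a fluorine atom, an amine or a carboxylic acid on the same carbon would test it. Also open, going by these compounds, is whether the hydroxy keeps its advantage on another carbon of the ring, and whether the order of the three compounds holds at other concentrations, since the read-out here is growth inhibition at a single concentration.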